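Piperazinyl phthalazine amides: swapping the anilide fluorine pattern

The compounds below may be only part of what the source reports. "The series", "measured", "known", "first", "only" and "open" are said of these compounds alone.

Measured so far:
Compound 1, `O=C(CN1CCN(c2nnc(Cc3ccccc3)c3ccccc23)CC1)Nc1c(F)cccc1F`, gives 19700 nM in a functional assay on HT-29 cells (Homo sapiens) for cytotoxicity, read by MTT assay, with a stated time of 72 h; a higher number here means a weaker inhibitor, a lower number a stronger inhibitor.
Compound 2, `O=C(CN1CCN(c2nnc(Cc3ccncc3)c3ccccc23)CC1)Nc1cccc(F)c1`, gives 6130 nM in this assay.

Compound 2 holds the lowest number of the two; its gap to compound 1 lies beyond the scatter. Compound 1 and compound 2 differ in two places, so neither change can be weighed on its own.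

Compound 3, `O=C(CN1CCN(c2nnc(Cc3ccncc3)c3ccccc23)CC1)Nc1c(F)cccc1F`, carries the change (2,6-difluorophenyl in place of 3-fluorophenyl on an amide-type nitrogen). Compound 1 also carries the 2,6-difluorophenyl anilide and stands weaker, so a step toward a higher number from compound 2 to compound 3 is expected, a 2.0-fold higher number from compound 2 to compound 3 (0.29 log units; within the scatter), though it may stay within the scatter. Compound 3 is estimated at 12000 nM, range 4000 nM to 35000 nM.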

Compound 3, half-maximal inhibitory concentration: 28700 nM
Estimate against measurement, compound 3: 2.4-fold (0.38 log units) below, and the stated range covers the measured number.
By their numbers in this assay, from the lowest: compound 2; then compounds 1 and 3 (each within the scatter of the next).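

With pyridin-4-yl held fixed, 2,6-difluorophenyl in place of 3-fluorophenyl on the amide-type nitrogen gives a 4.7-fold higher number from compound 2 to compound 3 (0.67 log units; beyond the scatter) in this assay, so the anilide fluorine pattern alone moves the read-out beyond the scatter. With the 2,6-difluorophenyl anilide held fixed, pyridin-4-yl in place of phenyl gives a 1.5-fold higher number from compound 1 to compound 3 (0.16 log units; within the scatter), a swap that stays within the scatter. Nothing in hand bears on the reason for either result.

On these data alone, the 3-fluorophenyl anilide appears only with pyridin-4-yl, so whether the anilide step carries over to the phenyl compounds stays open. As far as these compounds go, how a carboxylic acid or an amine in place of the fluorines on the anilide would read also remains open.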